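An Allyl Group on the Core Nitrogen of Compound 1

The source may hold more compounds than are shown below. What is called first, only, known or untested is meant among the compounds shown, and "the series" means these compounds.

Compound 1 `CN1CCN(CCNC(=O)n2c(=O)[nH]c3ccccc32)CC1` is the only one of the three measured compounds that gives a number in an assay on isolated protein for displacement of a labelled ligand from 5-hydroxytryptamine receptor 4 (Cavia porcellus); a lower number here means a stronger inhibitor, a higher number a weaker inhibitor; in that assay compound 1 gives 1000 nM. Compound 2 `CC(C)n1c(=O)n(C(=O)NCCCN2CCN(C)CC2)c2ccccc21` gives only a limit of the assay in this assay, > 1000 nM. Compound 3 `CCCCn1c(=O)n(C(=O)NCCN2CCN(C)CC2)c2ccccc21` likewise gives only a limit in this assay, > 1000 nM. Compound 4 `C=CCn1c(=O)n(C(=O)NCCN2CCN(C)CC2)c2ccccc21` has not yet been measured. It differs from compound 1 in one place (allyl in place of hydrogen on an aromatic nitrogen), so the hydrogen on the ring nitrogen of the shared core is replaced by a short chain carrying one double bond.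

Among the compounds with values here, the only measured step of the same kind is a number no lower from compound 1 to compound 3 (the limit leaves the size open). Because both compound 2 and compound 3 sit at the limit of > 1000 nM in this assay, at which 2 of the 3 values shown sit, the size of that step cannot be read. The direction, however, is known: a substituent on that nitrogen did not give a lower number. For compound 4 in this assay the expectation is therefore a number no lower than that of compound 1, with a fair chance that again only a limit appears. The step from compound 1 to compound 4 is expected to be a 2.0-fold higher number from compound 1 to compound 4 (0.30 log units; within the scatter). Compound 4 is estimated at 2000 nM, within a range from 700 nM to 6000 nM.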

Compound 4, half-maximal inhibitory concentration: > 1000 nM
Compound 4: no number, only a limit (the forecaster's own chance of this, stated with the estimate: 60%); the middle value does not contradict the limit.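

In this assay this position on the aromatic nitrogen has now taken a second substituent on the same side chain, and the step reads a number no lower from compound 1 to compound 4 (the limit leaves the size open). Compound 3 carries butyl there and compound 4 carries allyl, so a shorter chain with one double bond gave no number where the saturated butyl chain gave none either. Neither compound can be ranked against the other or sized against compound 1, since these steps cannot be read and most of the series now rests on a limit: the limit of > 1000 nM in this assay, at which 3 of the 4 values shown sit.

From the compounds shown here alone, how far compound 3 and compound 4 lie from compound 1 stays open, as does whether a smaller group such as methyl, or a chain ending in an amine or a carboxylic acid, would give a number on this nitrogen in this assay. The compounds shown also leave open what a chlorine atom elsewhere on the shared core would do.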